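A Hexyloxy Variant of Compound 2: Expected Activity

The source may hold more compounds than are shown below. What is called first, only, known or untested is meant among the compounds shown, and "the series" means these compounds.

Three compounds have been measured so far:

Compound 1, `COc1ccc(/C=C/c2cc(OC)cc(OC)c2/C=C/C(=O)c2ccc(Cl)c(Cl)c2)cc1`: 5.9 ug/mL
Compound 2, `CCCC(C)Oc1ccc(C(=O)/C=C/c2c(/C=C/c3ccc(OC)cc3)cc(OC)cc2OC)cc1`: 9.4 ug/mL
Compound 3, `COc1ccc(/C=C/c2cc(OC)cc(OC)c2/C=C/C(=O)c2cccc(Br)c2)cc1`: 8.1 ug/mL

All three share one core and differ only in the aryl group on the carbonyl carbon. They were tested in a functional assay on A549 cells (Homo sapiens) for antiproliferative activity, read by MTT assay, with a stated time of 48 h; a lower number here means a stronger inhibitor, a higher number a weaker inhibitor. Compound 2 has the highest of the three numbers, but its distance to the others is small: a 1.2-fold lower number from compound 2 to compound 3 (0.06 log units; within the scatter), and a 1.6-fold higher number from compound 1 to compound 2 (0.20 log units; within the scatter). The third comparison, a 1.4-fold higher number from compound 1 to compound 3 (0.14 log units; within the scatter), is likewise within the scatter. So no compound among the three can be called stronger or weaker than another.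

Compound 4, `CCCCCCOc1ccc(C(=O)/C=C/c2c(/C=C/c3ccc(OC)cc3)cc(OC)cc2OC)cc1`, has not yet been measured. It differs from compound 2 in one place: hexyl in place of 1-methylbutyl on an oxygen on an aromatic ring. For the measured compounds named here, none of the measured steps touches this alkoxy chain; all three concern the aryl group on the carbonyl carbon, and all three were within the scatter. There is therefore no direct guide for the chain change, and the only pattern so far is that the numbers in this assay stay close together.

Compound 4 is accordingly expected to give 9 ug/mL, with a range from 4.5 ug/mL to 18 ug/mL. This expectation means a step of a 1.0-fold lower number from compound 2 to compound 4 (0.02 log units; within the scatter), which is estimated to remain within the scatter.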

Compound 4, half-maximal inhibitory concentration: 8.4 ug/mL
The estimate for compound 4 lay 1.1-fold (0.03 log units) above the measured number, and the stated range covers the measured number.
By their numbers in this assay, from the lowest: compounds 1, 3, 4 and 2 (each within the scatter of the next).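

In this assay, hexyl in place of 1-methylbutyl on an oxygen on an aromatic ring gives a 1.1-fold lower number from compound 2 to compound 4 (0.05 log units; within the scatter). For the compounds shown here, the earlier steps all concerned the aryl group on the carbonyl carbon, so this is the only comparison that speaks to the alkyl chain on that oxygen, and it shows that these two chains cannot be told apart in this read-out, at least on the core shared by compound 2 and compound 4. Nothing available here bears on the reason for this result.

Going by these compounds, this single step covers only 1-methylbutyl and hexyl, so it remains open whether a much longer chain such as dodecyl, a much shorter one such as methyl, or a chain ending in an amine or a carboxylic acid would also stay within the scatter of compound 2. On these data alone, it also remains open whether a hexyloxy group would give a similar number if the rest of the aryl group carried chlorine or bromine, as the aryl groups of compound 1 and compound 3 do.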